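Pyridinylethoxy for fluorophenylpropyl: stability outlook

This account rests on a few compounds, and the source may have more. Where it says the series, first, only, none or still open, it means among the compounds named here.

Compound 1 `COc1ccc(CCOc2ccc(-c3c(C)nc(C)c([C@H](OC(C)(C)C)C(=O)O)c3N3CCC(C)(C)CC3)cc2)cc1`: in an ADME assay on microsomes from liver (Homo sapiens) for metabolic stability, read by LC-MS, tested at 0.5 uM (a higher number here means that the compound lasts longer, a lower number that the compound disappears faster), compound 1 gives > 2 h, a limit of the assay.
Compound 2 `COc1cccc(CCOc2ccc(-c3c(C)nc(C)c([C@H](OC(C)(C)C)C(=O)O)c3N3CCC(C)(C)CC3)cc2)c1`: in this assay compound 2 gives > 2 h, a limit of the assay.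
Compound 3 `Cc1nc(C)c([C@H](OC(C)(C)C)C(=O)O)c(N2CCC(C)(C)CC2)c1-c1ccc(CCCc2ccc(F)cc2)cc1`: in this assay compound 3 gives > 2 h, a limit of the assay.

Compound 3 therefore stands at the upper edge of what this assay reports, with no number of its own. The same holds for the whole set: the limit of > 2 h in this assay, at which 3 of the 3 values shown sit. Because every value is a limit, the steps between the measured compounds cannot be read: a step that the two limits leave unreadable from compound 1 to compound 2, a step that the two limits leave unreadable from compound 1 to compound 3 and a step that the two limits leave unreadable from compound 2 to compound 3 are each unreadable in size.

Compound 4 `Cc1nc(C)c([C@H](OC(C)(C)C)C(=O)O)c(N2CCC(C)(C)CC2)c1-c1ccc(OCCc2ccccn2)cc1` carries the shared core and differs from compound 3 in one place: 2-(pyridin-2-yl)ethoxy in place of 3-(4-fluorophenyl)propyl on an aromatic carbon. The two steps that end at compound 3, from compound 1 and from compound 2, are the ones that bear on this change, and both show only that the limit was held. Nothing measured here distinguishes an aryl-ethoxy side chain from an aryl-propyl one, so no step beyond the scatter is expected in either direction, and the step from compound 3 to compound 4 is estimated at a step that the limit leaves unreadable from compound 3 to compound 4. Compound 4 is estimated at 3 h, within 1.2 h to 8 h, most likely reported again as a limit.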

Compound 4, half-life: 0.5 h
Compound 4: middle estimate off by 6.0-fold (0.78 log units), on the high side; measured number outside the range, below it.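

Among the compounds shown, the side chain on this aromatic carbon, para to a large group, had never brought the half-life down from the limit; 2-(pyridin-2-yl)ethoxy in place of 3-(4-fluorophenyl)propyl does, giving an at least 4.0-fold lower number from compound 3 to compound 4 (0.60 log units; beyond the scatter). The ethoxy link alone is not enough for such a drop, since compound 1 and compound 2 carry the same link and remain at the limit, so the aromatic ring at the end of the chain matters: with pyridin-2-yl in place of the methoxyphenyl ring, the result is an at least 4.0-fold lower number from compound 1 to compound 4 (0.60 log units; beyond the scatter) and an at least 4.0-fold lower number from compound 2 to compound 4 (0.60 log units; beyond the scatter). Each of these steps gives only a minimum size, as each starts from a limit and not from a number: the limit of > 2 h in this assay, at which 3 of the 4 values shown sit.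

As far as these compounds go, the steps among compound 1, compound 2 and compound 3 still cannot be read, so how these three compare with one another stays unknown. Also open, from the compounds shown here alone, is whether a plain phenyl or a pyridin-3-yl on the same ethoxy chain would stay at the limit or fall as compound 4 does, and whether 3-(pyridin-2-yl)propyl, without the chain oxygen, would do the same.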